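Leaving 4-methylquinazolin-2-yl for 4-methoxyphenyl

This account rests on a few compounds, and the source may have more. Where it says the series, first, only, none or still open, it means among the compounds named here.

Among the compounds with values here, in a functional assay on PC-9 cells (Homo sapiens) for inhibition, read by MTT assay, with a stated time of 72 h (a higher number here means a weaker inhibitor, a lower number a stronger inhibitor), compound 3 (`Cc1cc(Nc2ccn(Cc3nc(C)c4ccccc4n3)n2)n2nc(SCc3ccc(Br)cc3)nc2n1`) gives 5450 nM, the lowest number measured so far. Compound 2 (`Cc1cc(Nc2ccn(Cc3ccc(F)cc3)n2)n2nc(SCc3ccc(Br)cc3)nc2n1`) gives 19400 nM. Compound 1 (`Cc1cc(Nc2ccn(Cc3ccccc3)n2)n2nc(SCc3ccc(Br)cc3)nc2n1`) reads > 50000 nM, which is a limit of the assay.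

Compound 4 (`COc1ccc(Cn2ccc(Nc3cc(C)nc4nc(SCc5ccc(Br)cc5)nn34)n2)cc1`) differs from compound 3 as follows: 4-methoxyphenyl in place of 4-methylquinazolin-2-yl on a saturated chain carbon bound to an aromatic nitrogen. Within the data shown here, the closest precedent is a 3.6-fold lower number from compound 2 to compound 3 (0.55 log units; beyond the scatter), here run in reverse, with a substituted phenyl returning. Also relevant are an at least 2.5-fold lower number from compound 1 to compound 2 (0.41 log units; beyond the scatter) and an at least 9.1-fold lower number from compound 1 to compound 3 (0.96 log units; beyond the scatter), which both start from the limit. A higher number of similar size to the first of these is therefore expected, an estimated 3.1-fold higher number from compound 3 to compound 4 (0.49 log units; beyond the scatter). Compound 4 is estimated at 17000 nM, with an expected range of 6000 nM to 50000 nM.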

Compound 4, half-maximal inhibitory concentration: > 50000 nM
Compound 4: only a limit was reported; the forecaster's own chance of this, stated with the estimate: 20%; middle value at least 2.9-fold (0.46 log units) from the limit.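

In this assay, the 4-methylquinazolin-2-yl on this saturated chain carbon proves clearly better than 4-methoxyphenyl, with an at least 9.1-fold higher number from compound 3 to compound 4 (0.96 log units; beyond the scatter). Methoxy in place of fluoro on the aromatic carbon also loses ground, with an at least 2.5-fold higher number from compound 2 to compound 4 (0.41 log units; beyond the scatter), so the gain seen with fluoro does not extend to every group there, and compound 4 goes against any general benefit of substitution. The step between compound 1 and compound 4 cannot be read, as both values are limits: the limit of > 50000 nM in this assay, at which 2 of the 4 values shown sit.

As far as these compounds go, whether an amine or a carboxylic acid in place of the methoxy would lower the number remains open. So does the part played by the 4-methyl of the quinazoline.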